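The source may report more compounds than this note shows. Statements on the series, on what has been measured and on what is new or still open speak of the compounds shown alone.

In a functional assay on Huh-7 cells (Homo sapiens) for inhibition, read by CCK-8 assay, with a stated time of 72 h (on this read-out lower numbers stand for stronger inhibition and higher numbers for weaker inhibition), compound 1 (`O=C(/C=C/c1cccnc1)NCCCc1ccc(S(=O)(=O)Nc2ccccc2)cc1`) returns only a limit of the assay (> 10000 nM). For the measured compounds named here, compound 2 (`Cc1cccc(NS(=O)(=O)c2cccc(CCCCCCNC(=O)/C=C/c3cccnc3)c2)c1`) gives the only actual number so far (13.2 nM). Compound 3 (`O=C(/C=C/c1cccnc1)NCCCCCCc1cccc(S(=O)(=O)Nc2ccc(C(F)(F)F)cc2)c1`) carries 4-(trifluoromethyl)phenyl in place of 3-methylphenyl on a sulfonamide nitrogen. Going by the values given here, no measured step covers this change, so the expectation in this assay is tentative: a small loss of inhibition, perhaps not much beyond the usual scatter, with an expected step (a 1.9-fold higher number from compound 2 to compound 3 (0.28 log units; within the scatter)). Compound 3 is estimated at 25 nM in this assay, with an expected range from 4 nM to 200 nM.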

Compound 3, half-maximal inhibitory concentration: 164 nM
For compound 3 the middle estimate is 6.6-fold (0.82 log units) below the measured one; the measured number falls inside the stated range.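

Inhibition in this assay proves sensitive to the group on the sulfonamide nitrogen: 4-(trifluoromethyl)phenyl in place of 3-methylphenyl gives a 12-fold higher number from compound 2 to compound 3 (1.09 log units; beyond the scatter). Even so, compound 3 retains a measured value of 164 nM, so this change weakens inhibition without abolishing it. Nothing shown here accounts for the loss.

The step from compound 2 to compound 3 alters both the substituent and its place on the ring, so it cannot separate the two. A 3-(trifluoromethyl)phenyl or a 4-methylphenyl group on the same nitrogen would be needed to tell them apart.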